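The compounds below may be only part of what the source reports. "The series", "measured", "known", "first", "only" and "open" are said of these compounds alone.

Measured so far:
compound 1, `COc1cccc(S(=O)(=O)c2cnc3cc(F)ccc3c2-c2cccc(Cl)c2)c1`: 2.97 mL/min
compound 2, `O=S(=O)(c1cc(Cl)cc(Cl)c1)c1cnc2cc(F)ccc2c1-c1ccc(Cl)cc1`: 0.13 mL/min
compound 3, `COc1cccc(S(=O)(=O)c2cnc3cc(F)ccc3c2-c2cccc(F)c2)c1`: 3.36 mL/min

In an ADME assay on microsomes from liver (Homo sapiens) for metabolic stability, tested at 2.5 uM (a lower number here means slower removal, a higher number faster removal of the compound), compound 1 stands second highest of the three numbers. Going by the values given here, compound 3 sits within the scatter of it, the only one-place step being a 1.1-fold higher number from compound 1 to compound 3 (0.05 log units; within the scatter). Compound 2, which carries a dichlorophenyl rather than a methoxyphenyl on the sulfonyl sulfur, gives a far lower number than compound 1.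

Compound 4, `O=S(=O)(c1ccc(F)c(F)c1)c1cnc2cc(F)ccc2c1-c1cccc(Cl)c1`, differs from compound 1 in one place: 3,4-difluorophenyl in place of 3-methoxyphenyl on a sulfonyl sulfur. Among the compounds with values here, no measured one-place step matches this change. The step from compound 1 to compound 3, on the other aryl ring, was within the scatter, while the value of compound 2 shows that a sulfonyl aryl without the methoxy can give a much lower number. A moderately lower number is therefore expected for compound 4, a 3.0-fold lower number from compound 1 to compound 4 (0.47 log units; beyond the scatter), with the estimate 1 mL/min and a range from 0.3 mL/min to 3 mL/min.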

Compound 4, intrinsic clearance in a liver preparation (reported as CLH), per the amount of preparation that the assay uses: 0.38 mL/min
Compound 4: the middle estimate sits 2.6-fold (0.42 log units) above what was measured; low and high end bracket the measured number.
By their numbers in this assay, from the lowest: compound 2; then compound 4; then compounds 1 and 3 (each within the scatter of the next).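

In this assay, 3,4-difluorophenyl in place of 3-methoxyphenyl on the sulfonyl sulfur gives a 7.8-fold lower number from compound 1 to compound 4 (0.89 log units; beyond the scatter). Going by these compounds alone, this is the first one-place step at this position, and it lies beyond the scatter, whereas the change on the other aryl ring, a 1.1-fold higher number from compound 1 to compound 3 (0.05 log units; within the scatter), stayed within it. The number therefore responds to the aryl group on the sulfonyl sulfur with the rest of compound 1 held fixed. The compounds shown do not separate removing the methoxy from adding the fluorines, and how a pyridine ring, an amine or a carboxylic acid would behave at this position remains open. No evidence at hand explains this step.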